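One Four-Membered Ring Replaces Another on the Shared Core

The source may hold more compounds than are shown below. What is called first, only, known or untested is meant among the compounds shown, and "the series" means these compounds.

Compound 1 `Cc1cc(COc2cccc(S(C)(=O)=O)c2)nc(-c2ccccn2)n1`: > 39800 nM (a limit)
Compound 2 `Cc1cc(COc2c(F)cc(F)cc2F)nc(-c2ccccn2)n1`: 1260 nM
Compound 3 `CC1(CS(C)(=O)=O)CN(c2cc(COc3ccc(F)c(F)c3F)nc(-c3ccccn3)n2)C1`: 6310 nM

In a functional assay on cells for antagonist activity at Free fatty acid receptor 1 (Homo sapiens), read by TR-FRET and inositol phosphate accumulation, with a stated time of 2 h (on this read-out lower numbers stand for stronger inhibition and higher numbers for weaker inhibition), compound 1 sits at the limit of > 39800 nM in this assay, at which 1 of the 3 values shown sits, which is a limit of the measurement and not a number. Among the two real numbers, compound 3 has the higher one, and its gap to compound 2 lies beyond the usual scatter. Compound 4 `Fc1ccc(OCc2cc(OCC3(F)COC3)nc(-c3ccccn3)n2)c(F)c1F` is not yet measured. It differs from compound 3 by (3-fluorooxetan-3-yl)methoxy in place of 3-methyl-3-((methylsulfonyl)methyl)azetidin-1-yl on an aromatic carbon. Among the compounds with values here, no measured pair shows this kind of exchange, so the expectation rests on the spread seen so far: since compound 2, without either of these groups, gives 1260 nM, a modest move toward a lower number is expected, a 2.0-fold lower number from compound 3 to compound 4 (0.29 log units; within the scatter). For compound 4 the estimated value in this assay is 3200 nM, with a likely range from 800 nM to 12000 nM.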

Compound 4, half-maximal inhibitory concentration: 63.1 nM
Estimate against measurement, compound 4: 51-fold (1.71 log units) above; measured number below the stated range.
By their numbers in this assay, from the lowest: compound 4; then compound 2; then compound 3. At a limit, above all of these: compound 1.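

In this assay the group on this aromatic carbon turns out to matter greatly: (3-fluorooxetan-3-yl)methoxy in place of 3-methyl-3-((methylsulfonyl)methyl)azetidin-1-yl gives a 100-fold lower number from compound 3 to compound 4 (2.00 log units; beyond the scatter), a large step. Both groups hold a four-membered non-aromatic ring with one hetero atom, so that ring alone does not set the result. No measurement shown accounts for the size of this step. Which part of the entering group carries the step stays open. So does what a plain methoxy group or an amine would give on this carbon.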